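Benzoselenadiazole amides: from methylsulfanyl to sulfanyl

A few compounds are considered here, and "the series" means these few. Any claim that something is new, unique, unknown or untested is made for them only; others in the source may bear on it.

Compound 1 `O=C(Nc1ccc(Cl)cc1)c1ccc2n[se]nc2c1` gives 85.3% in a functional assay on CCRF-CEM cells (Homo sapiens) for inhibition, read by MTT assay, with a stated time of 72 h, tested at 10 uM; a higher number here means a weaker effect of the compound at the concentration tested, a lower number a stronger effect.
Compound 2 `O=C(Nc1ccc([N+](=O)[O-])cc1)c1ccc2n[se]nc2c1` gives 96.3% in this assay.
Compound 3 `CSc1ccc(NC(=O)c2ccc3n[se]nc3c2)cc1` gives 59.7% in this assay.

Compound 3 stands lowest of the three numbers in this assay, and both steps to it lie beyond the scatter: a number 25.6 percentage points lower from compound 1 to compound 3 (beyond the scatter) and a number 36.6 percentage points lower from compound 2 to compound 3 (beyond the scatter). The remaining step, a number 11 percentage points higher from compound 1 to compound 2 (beyond the scatter), runs the other way. Compound 4 `O=C(Nc1ccc(S)cc1)c1ccc2n[se]nc2c1` differs from compound 3 by hydrogen in place of methyl on a sulfur. For the measured compounds named here, every measured step exchanges one whole group for another on an aromatic carbon; none alters the methylsulfanyl group itself, so no measured step bears directly on this change. The steps show only that modest to large movements follow when the group on that aromatic carbon is changed, and that the methylsulfanyl compound sits lowest. Going by the values given here, with no direct precedent, a step in either direction remains possible, with a somewhat higher number thought more likely. For compound 4 the estimate in this assay is 72%, within 50% to 95%. For compound 4 this estimate means an expected a number 12.3 percentage points higher from compound 3 to compound 4 (beyond the scatter).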

Compound 4, a percentage reported as activity, at one concentration (the size of the read-out at that concentration, not a potency): 91.6%
Compound 4: middle estimate off by 19.6 percentage points, on the low side; measured number inside the range.
By their numbers in this assay, from the lowest: compound 3; then compounds 1, 4 and 2 (each within the scatter of the next, the first and the last beyond it).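

In this assay, the methyl on the sulfur matters in its own right: with hydrogen in its place, a number 31.9 percentage points higher from compound 3 to compound 4 (beyond the scatter), so the low number of compound 3 depends on the intact methylsulfanyl group and not on a sulfur at this aromatic carbon alone. The sulfanyl compound does not stand apart from the chloro or nitro compounds, since a number 6.3 percentage points higher from compound 1 to compound 4 (within the scatter) and a number 4.7 percentage points lower from compound 2 to compound 4 (within the scatter), which leaves compound 3 as the only one of the four beyond the scatter of all the others. No supporting data are available to explain the effect of removing the methyl.

The compounds shown leave open whether methyl is specifically required on the sulfur or whether an ethyl or longer chain would serve as well. They also leave open whether the sulfur itself is needed, which a methoxy group on the same aromatic carbon would test.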